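This account rests on a few compounds, and the source may have more. Where it says the series, first, only, none or still open, it means among the compounds named here.

Measured so far:
Compound 1 `Cc1cc(-c2nc3n(c2/C=N/NC(=N)N)CCS3)c(C)s1` gives 15500 nM in a functional assay on cells (Melanoma cell, Homo sapiens) for inhibition; a higher number here means a weaker inhibitor of growth, a lower number a stronger inhibitor of growth.
Compound 2 `N=C(N)N/N=C/c1c(-c2cccs2)nc2sccn12` gives 15100 nM in this assay.

Both numbers are large, so neither compound holds back growth strongly. Compound 1 shows the higher of the two numbers, but its gap to compound 2 lies within the usual scatter, so the two cannot be told apart on these data. Compound 3 `N=C(N)N/N=C/c1c(-c2cc(Cl)sc2Cl)nc2n1CCS2` has not yet been measured. It differs from compound 1 in one place: 2,5-dichlorothiophen-3-yl in place of 2,5-dimethylthiophen-3-yl on an aromatic carbon. The group that leaves and the group that enters match in their count of heavy atoms and of hydrogen-bond acceptors. Going by the values given here, no measured pair here shows what such a swap does, so the step from compound 1 to compound 3 in this assay is expected to be small, with no clear direction beyond the scatter. On that basis compound 3 is estimated at 12000 nM, with a range from 4000 nM to 35000 nM. This estimate means a step of a 1.3-fold lower number from compound 1 to compound 3 (0.11 log units; within the scatter) is expected.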

Compound 3, concentration for 50% growth inhibition: 10000 nM
The estimate for compound 3 lay 1.2-fold (0.08 log units) above the measured number, within the range that was stated.
By their numbers in this assay, from the lowest: compounds 3, 2 and 1 (each within the scatter of the next).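

Going by these compounds alone, this is the first measured swap at this position, the aromatic carbon of the five-membered ring with 2 nitrogen in the shared core. In this assay, 2,5-dichlorothiophen-3-yl in place of 2,5-dimethylthiophen-3-yl gives a 1.6-fold lower number from compound 1 to compound 3 (0.19 log units; within the scatter), so exchanging the methyl groups on this thiophene for chlorine atoms produces no change that can be told from scatter. No measured information bears on this result, so nothing can be said about what lies behind it.

On these data alone, both methyl groups change together in this step, so the effect of each single place on the thiophene remains open, as a thiophene carrying one chlorine and one methyl could show. As far as these compounds go, it also remains open whether a more different group at this position, such as a phenyl ring bearing an amine or a carboxylic acid, would move the number beyond the scatter.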